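The source may hold more compounds than are shown below. What is called first, only, known or untested is meant among the compounds shown, and "the series" means these compounds.

In an ADME assay on HEK293 cells (Homo sapiens) for cytotoxicity, read by reporter gene assay and resazurin assay, with a stated time of 48 h (on this read-out higher numbers stand for lower toxicity in this test and lower numbers for higher toxicity in this test), three compounds sharing one core have been tested, and none gives a number. Compound 1 (`COc1ccc(Br)cc1C(=O)Nc1ccc(Sc2nc3ccccc3s2)cc1`) gives > 100000 nM, which is a limit of the assay. Compound 2 (`O=C(Nc1ccc(Sc2nc3ccccc3s2)cc1)c1cc(Br)cc(Br)c1`) gives > 100000 nM, again a limit. Compound 3 (`O=C(Nc1ccc(Sc2nc3ccccc3s2)cc1)c1ccccc1`) gives > 100000 nM, also a limit. Compound 3 therefore has no number of its own and stands with the other two at the limit of > 100000 nM in this assay, at which 3 of the 3 values shown sit.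

Compound 4 (`O=C(Nc1ccc(Sc2nc3ccccc3s2)c(Cl)c1)c1ccccc1`) differs from compound 3 by a single change, chloro in place of hydrogen on an aromatic carbon.

The nearest evidence comes from changes on the carbonyl carbon, namely a step that the two limits leave unreadable from compound 1 to compound 3 and a step that the two limits leave unreadable from compound 2 to compound 3. Neither has a readable size, and neither adds chloro, so they offer only weak guidance. Still, all three compounds reached the same limit despite those changes. The step expected in this assay is a number no higher from compound 3 to compound 4 (the limit leaves the size open), estimated to lie within the scatter, with no direction favoured. Compound 4 is estimated at 100000 nM, with an expected range from 40000 nM to 200000 nM.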

Compound 4, half-maximal cytotoxic concentration: 90000 nM
Estimate against measurement, compound 4: 1.1-fold (0.05 log units) above; low and high end bracket the measured number.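

Chloro on this aromatic carbon, ortho to a large group, gives the only true number among the compounds shown in this assay, whereas the earlier steps on the carbonyl carbon cannot be read. Compared directly, the change gives an at least 1.1-fold lower number from compound 3 to compound 4 (0.04 log units; that floor lies within the scatter). That is only a floor and it lies within the scatter, so chloro at this position may matter little or more than that, and the reading rests on a comparison with a limit, the position shared by the other compounds: the limit of > 100000 nM in this assay, at which 3 of the 4 values shown sit.

On these data alone, the true size of the step therefore stays open. So does whether fluoro, methoxy or an amine on this same carbon, or chloro on another carbon of this ring, would also give a number rather than a limit.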